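Ethoxycarbonyloxymethyl in Place of Pivaloyloxymethyl Ester

This account rests on a few compounds, and the source may have more. Where it says the series, first, only, none or still open, it means among the compounds named here.

Compound 1 `C[C@@H](O)[C@H]1C(=O)N2C(C(=O)OCOC(=O)C(C)(C)C)=C(S[C@@H]3CN[C@H](C(=O)Nc4cccc(C(=O)O)c4)C3)[C@H](C)[C@H]12` was examined in an ADME assay for metabolic stability, read by LC-MS, with a stated time of 3 h, at pH 6.5, tested at 50 uM; on this read-out lower numbers stand for a less stable compound and higher numbers for a more stable compound. In this assay compound 1 gives > 95%, which is a limit of the assay rather than a number. Compound 2 `CC(OC(=O)C1=C(S[C@@H]2CN[C@H](C(=O)Nc3cccc(C(=O)OC(C)OC(=O)C(C)(C)C)c3)C2)[C@H](C)[C@@H]2[C@@H]([C@@H](C)O)C(=O)N12)OC(=O)C(C)(C)C` also reaches a limit. In this assay compound 2 gives > 95%. Compound 3 `CCOC(=O)C1=C(S[C@@H]2CN[C@H](C(=O)Nc3cccc(C(=O)OCC)c3)C2)[C@H](C)[C@@H]2[C@@H]([C@@H](C)OC(=O)[C@@H](N)C(C)C)C(=O)N12` is the third measured compound. In this assay compound 3 gives > 95%, again a limit. Going by the values given here, compound 1 thus stands at the limit of > 95% in this assay, at which 3 of the 3 values shown sit, so it cannot be placed above or below compound 2 or compound 3, and no step between any two of them is available.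

Compound 4 `CCOC(=O)OCOC(=O)C1=C(S[C@@H]2CN[C@H](C(=O)Nc3cccc(C(=O)O)c3)C2)[C@H](C)[C@@H]2[C@@H]([C@@H](C)O)C(=O)N12` has not yet been measured. It differs from compound 1 by ethoxy in place of tert-butyl on a carbonyl carbon. Among the compounds with values here, because no measured step exists between these compounds, there is nothing to show how large a change of this kind is in this assay. The author expects compound 4 to remain at the limit, with an expected step from compound 1 to compound 4 of a number no higher from compound 1 to compound 4 (the limit leaves the size open), nothing beyond the scatter. Compound 4 is accordingly estimated at 95%, in a range from 85% to 100%.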

Compound 4, percent of the compound remaining: > 95%
Compound 4 gave a limit, no number; the forecaster's own chance of this, stated with the estimate: 80%; the middle value sits exactly at the limit.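

In this assay compound 4 gives > 95%, a limit and not a number, so no step between compound 1 and compound 4 can be read: the limit of > 95% in this assay, at which 4 of the 4 values shown sit.

The compounds shown leave open whether ethoxy in place of tert-butyl on a carbonyl carbon changes stability at all.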